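The source may hold more compounds than are shown below. What is called first, only, known or untested is meant among the compounds shown, and "the series" means these compounds.

The measured compounds:
compound 1, `N#Cc1cnc(NC(=O)CCCOc2cccc(Cl)c2)s1`: 115 mL.min-1.g-1
compound 2, `Cc1cnc(NC(=O)NCCOc2ccc(Cl)c(C)c2)s1`: 105 mL.min-1.g-1
compound 3, `CC(C)c1cnc(NC(=O)CCCOc2ccccc2)s1`: 232 mL.min-1.g-1

All three were tested in an ADME assay on microsomes from liver (Homo sapiens) for metabolic stability, read by LC-MS, using NADPH, tested at 1 uM; on this read-out higher numbers stand for fast clearance and lower numbers for slow clearance. Compound 1 gives 115 mL.min-1.g-1, compound 2 gives 105 mL.min-1.g-1 and compound 3 gives 232 mL.min-1.g-1. Compound 3 holds the largest of the three numbers, but its gap to compound 1 lies within the scatter of the assay, so no order between those two can be claimed; only its gap to compound 2 lies beyond the scatter.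

Compound 4, `O=C(CCCOc1ccccc1)Nc1ncc(Cl)s1`, has not yet been measured in this assay. It differs from compound 3 in one place: chloro in place of isopropyl on an aromatic carbon. No step between two measured compounds matches this change, so there is no direct precedent for it among the numbers shown; the smaller substituents of compound 1 and compound 2 on the same ring sit at lower numbers than compound 3, but those compounds differ from compound 3 in more than one place.

On that slender basis the step from compound 3 to compound 4 is expected to be downward and modest, a 1.8-fold lower number from compound 3 to compound 4 (0.25 log units; within the scatter), close to the edge of the scatter. Compound 4 is therefore estimated to give 130 mL.min-1.g-1, with a range from 60 mL.min-1.g-1 to 280 mL.min-1.g-1.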

Compound 4, intrinsic clearance in microsomes in the Homo sapiens assay: 90 mL.min-1.g-1
Estimate against measurement, compound 4: 1.4-fold (0.16 log units) above, within the range that was stated.
By their numbers in the Homo sapiens assay, from the lowest: compounds 4, 2, 1 and 3 (each within the scatter of the next, the first and the last beyond it).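

In the Homo sapiens assay, chloro in place of isopropyl on the aromatic carbon next to the ring sulfur gives the first step among these compounds that changes this position alone, a 2.6-fold lower number from compound 3 to compound 4 (0.41 log units; beyond the scatter), so the number at this position can be followed without any change elsewhere in the molecule. In a physicochemical assay for solubility, read by nephelometry, in phosphate buffer, at pH 6.5 (on this read-out lower numbers stand for lower solubility and higher numbers for higher solubility), compound 3 gives < 1200 nM, which is a limit of the assay. In the physicochemical assay, compound 4 gives < 1200 nM, again a limit, and the step between the two cannot be read because both sit at the same limit: the limit of < 1200 nM in the physicochemical assay, at which 2 of the 2 values shown sit.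

A single pair cannot tell whether the lower number in the Homo sapiens assay goes with the smaller count of heavy atoms or with chlorine itself, and a fluoro, methoxy or cyclopropyl group at this position would be needed to separate the two. From the compounds shown here alone, it also remains open whether the same step would appear with the substituted phenoxy groups or the urea of the other compounds, and how any compound here stands in the physicochemical assay beyond the limit.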